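The compounds below may be only part of what the source reports. "The series", "measured", "known", "first", "only" and "open" are said of these compounds alone.

Measured in a functional assay on MDA-MB-231 cells (Homo sapiens) for antiproliferative activity, read by MTT assay, with a stated time of 48 h; on this read-out higher numbers stand for weaker inhibition and lower numbers for stronger inhibition:
- compound 1 `C=CS(=O)(=O)N1CCN(c2ncnc3sc(-c4ccc(C(F)(F)F)cc4)cc23)CC1`: 6410 nM
- compound 2 `C=CS(=O)(=O)N1CCN(c2nc(OC[C@H]3CCCN3C)nc3sc(-c4ccc(N5CCN(C)CC5)cc4)cc23)[C@@H](C)C1`: 2880 nM
- compound 3 `CCS(=O)(=O)N1CCN(c2ncnc3sc(-c4ccc(N5CCN(C)CC5)cc4)cc23)CC1`: 7330 nM

Compound 3 stands level with compound 1 within the scatter. Compound 2 has a lower number than compound 3, and that gap lies beyond the scatter.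

Compound 4 `CN1CCN(c2ccc(-c3cc4c(N5CCN(C(=O)Nc6ccc(Cl)cc6)CC5)ncnc4s3)cc2)CC1` carries (4-chlorophenyl)carbamoyl in place of ethylsulfonyl on an amine nitrogen in a ring. Among the measured compounds shown here, no pair of measured compounds differs in one place only, so this change has no direct precedent. For the measured compounds named here, the only guide is the spread of the measured numbers, which runs from compound 2 at 2880 nM to compound 3 at 7330 nM. A moderate move toward stronger inhibition is therefore expected, with no change beyond the scatter remaining a real possibility. The estimated change is a 2.3-fold lower number from compound 3 to compound 4 (0.36 log units; beyond the scatter). In this assay, the estimate for compound 4 is 3200 nM, with an expected range of 900 nM to 11000 nM.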

Compound 4, half-maximal inhibitory concentration: 5440 nM
Beside the measured number, compound 4's estimate is 1.7-fold (0.23 log units) below it; the measured number falls inside the stated range.
By their numbers in this assay, from the lowest: compounds 2, 4, 1 and 3 (each within the scatter of the next, the first and the last beyond it).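

In this assay, the exchange at this ring nitrogen gives a 1.3-fold lower number from compound 3 to compound 4 (0.13 log units; within the scatter), the first single-place comparison available in the series. The result shows that replacing ethylsulfonyl with the larger (4-chlorophenyl)carbamoyl, which brings an aromatic ring and the amide hydrogen, leaves the read-out level, so a sulfonyl link at this position is not needed to hold antiproliferative activity in this range. Nothing on hand bears on why this step stays within the scatter.

As far as these compounds go, it remains open whether this flat response extends to other groups on the same nitrogen, such as a simple acetyl, a benzyl or a carbamoyl bearing an unsubstituted phenyl. The contribution of the chlorine to the (4-chlorophenyl)carbamoyl group also remains unresolved.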